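Anilino substitution on the shared core: methyl to trifluoromethyl

This account rests on a few compounds, and the source may have more. Where it says the series, first, only, none or still open, it means among the compounds named here.

Measured so far:
compound 1 `Cc1ccc(Nc2nccc(-c3ccnc4ccccc34)n2)cc1`: 50.9%
compound 2 `Nc1nccc(-c2ccnc3ccccc23)n1`: 9.4%

Among the measured compounds shown here, in a functional assay on K562 cells (Homo sapiens) for cytotoxicity, read by sulforhodamine B assay, with a stated time of 48 h, tested at 50 uM (a lower number here means less inhibition, a higher number more inhibition at the concentration tested (going by the name of the read-out)), compound 1 gives 50.9%, the higher of the two numbers known. Compound 2 gives 9.4% in this assay. For the measured compounds named here, the one step between measured compounds is a number 41.5 percentage points lower from compound 1 to compound 2 (beyond the scatter), which shows that the whole anilino group on the core carries most of the inhibition seen for compound 1.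

Compound 3 `FC(F)(F)c1ccc(Nc2nccc(-c3ccnc4ccccc34)n2)cc1` differs from compound 1 by trifluoromethyl in place of methyl on an aromatic carbon. Going by the values given here, no measured step touches a change on the distal ring of the anilino group; the only step on record removes that ring entirely and says nothing about how a substituent on it shifts the number. The anilino group itself is retained in compound 3, so the large drop from compound 1 to compound 2 is not expected to recur. Among the compounds with values here, with no bearing step, the expected step of a number 0.9 percentage points lower from compound 1 to compound 3 (within the scatter) is none beyond the scatter, in either direction. The estimate for compound 3 in this assay is 50%, with a range from 30% to 70%, expected to stay near compound 1.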

Compound 3, a percentage reported as inhibition, at one concentration (the size of the read-out at that concentration, not a potency): "not active" (no number reported)
For compound 3 the study gives words and no number; no gap can be computed for the estimate.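

In this assay, among the compounds shown here, compound 3 is reported as not active, with no number, so no step from compound 1 to compound 3 can be read. The compounds shown leave open how large the gap between these two is when trifluoromethyl replaces methyl. No supporting measurement shown bears on this result.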